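The source may report more compounds than this note shows. Statements on the series, on what has been measured and on what is new or still open speak of the compounds shown alone.

Within the data shown here, compound 2 `COC(=O)CCCC(=O)Nc1cccc(OCc2ccc3ccccc3c2)c1` gives 12600 nM in an assay on isolated protein for inhibition of Polyunsaturated fatty acid 5-lipoxygenase (Rattus norvegicus) (a lower number here means a stronger inhibitor, a higher number a weaker inhibitor), and stands at one end of the two numbers so far, separated from compound 1 `COC(=O)C(=O)Nc1cccc(OCc2ccc3ccccc3c2)c1`, which gives 6900 nM, only by a step within the scatter. Compound 3 `COC(=O)CC(=O)Nc1cccc(OCc2ccc3ccccc3c2)c1` carries methoxycarbonyl in place of 2-(methoxycarbonyl)ethyl on a saturated chain carbon bound to a carbonyl carbon. Among the measured compounds shown here, the one measured step that bears on this chain length, a 1.8-fold higher number from compound 1 to compound 2 (0.26 log units; within the scatter), stayed within the scatter, so no movement beyond the scatter is expected in this assay. The expected step is a 1.3-fold lower number from compound 2 to compound 3 (0.12 log units; within the scatter). Compound 3 is estimated at 9500 nM, with a range from 4500 nM to 20000 nM.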

Compound 3, half-maximal inhibitory concentration: 9500 nM
For compound 3 middle estimate and measured number coincide at the digits printed; measured number inside the range.
By their numbers in this assay, from the lowest: compounds 1, 3 and 2 (each within the scatter of the next).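

In this assay a third chain length joins the series: going from 3-(methoxycarbonyl)propyl to (methoxycarbonyl)methyl gives a 1.3-fold lower number from compound 2 to compound 3 (0.12 log units; within the scatter) and going from methoxycarbonyl to (methoxycarbonyl)methyl on the carbonyl carbon gives a 1.4-fold higher number from compound 1 to compound 3 (0.14 log units; within the scatter) and both steps stay within the scatter. Compound 1, compound 2 and compound 3 are therefore not told apart, and no dependence on chain length can be read from them.

Open, as far as these compounds go, is whether, in this assay and on the same core, a carboxylic acid or an amine in place of methoxycarbonyl, or a longer chain, would move the number beyond the scatter. No data are available that bear on this result.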